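The compounds below may be only part of what the source reports. "The series", "measured", "known", "first", "only" and "open" are said of these compounds alone.

For the measured compounds named here, in an ADME assay on Vero cells (Chlorocebus sabaeus) for cytotoxicity, read by MTT assay (a higher number here means a weaker inhibitor, a lower number a stronger inhibitor), compound 1 (`CCC(C)CC(=O)OCC(C)(C)CC1=C(O)C(=O)c2ccccc2C1=O`) gives 2300 nM, and compound 2 (`CCCCCCCCC(=O)OCC(C)(C)CC1=C(O)C(=O)c2ccccc2C1=O`) gives 150000 nM, the higher of the two numbers so far. Compound 3 (`CCCCCCCCCC(=O)OCC(C)(C)CC1=C(O)C(=O)c2ccccc2C1=O`) differs from compound 2 by one change: methyl in place of hydrogen on a saturated chain carbon, eight bonds along the chain from a carbonyl carbon. Going by the values given here, only one measured step bears on this: a 65-fold higher number from compound 1 to compound 2 (1.81 log units; beyond the scatter), a large one, where heptyl replaced sec-butyl. Methyl in place of hydrogen is a smaller change than that, so a modest rise is expected, possibly no larger than the scatter. The estimated step is a 1.3-fold higher number from compound 2 to compound 3 (0.12 log units; within the scatter). For compound 3 the expected value is 200000 nM, with an estimated range from 80000 nM to 500000 nM.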

Compound 3, half-maximal inhibitory concentration: 203000 nM
For compound 3 the middle estimate is 1.0-fold (0.01 log units) below the measured one; the measured number falls inside the stated range.
By their numbers in this assay, from the lowest: compound 1; then compounds 2 and 3 (each within the scatter of the next).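

In this assay, methyl in place of hydrogen on a saturated chain carbon, eight bonds along the chain from a carbonyl carbon, gives a 1.4-fold higher number from compound 2 to compound 3 (0.13 log units; within the scatter) and so does not separate these two compounds. Octyl in place of sec-butyl gives an 88-fold higher number from compound 1 to compound 3 (1.95 log units; beyond the scatter) and shows that compound 3, like compound 2, stands far from compound 1. No measurement shown here explains either result. A straight butyl chain could show where the large step arises between sec-butyl and heptyl. As far as these compounds go, a longer chain such as decyl, or an amine at the chain end, remains open.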